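The source may report more compounds than this note shows. Statements on the series, on what has been measured and on what is new or still open speak of the compounds shown alone.

Measured in an in vitro functional assay on HEK293-A cells for agonist activity at metabotropic glutamate receptor 5 (Rattus norvegicus), read by ELISA; a higher number here means a weaker inhibitor, a lower number a stronger inhibitor:

compound 1 `N#Cc1cc(F)cc(C#Cc2cccc(F)n2)c1`: 80 nM
compound 2 `CC(=O)c1cccc(C#Cc2cc(F)cc(C#N)c2)n1`: 240 nM
compound 3 `N#Cc1cccc(C#Cc2cccc(F)n2)c1`: 210 nM

Two single changes connect these. From compound 1 to compound 2 the change is acetyl in place of fluoro on an aromatic carbon, and in this assay it gives a 3.0-fold higher number from compound 1 to compound 2 (0.48 log units; beyond the scatter). From compound 1 to compound 3 the change is hydrogen in place of fluoro on an aromatic carbon, and in this assay it gives a 2.6-fold higher number from compound 1 to compound 3 (0.42 log units; beyond the scatter). Compound 2 and compound 3 are not connected by a single change; their values sit within the usual scatter of each other, so no order between them is drawn.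

Compound 4 `CC(=O)c1cccc(C#Cc2cccc(C#N)c2)n1` has not been measured in this assay. It differs from compound 3 by acetyl in place of fluoro on an aromatic carbon. This is the same change as from compound 1 to compound 2, on the same ring and at the same place, word for word. The two cores differ only by hydrogen in place of fluoro on an aromatic carbon, which is the difference between compound 1 and compound 3 described above. With one prior example of the change, the expectation for compound 3 to compound 4 in this assay is a step of a 2.9-fold higher number from compound 3 to compound 4 (0.46 log units; beyond the scatter), set beside the earlier step because of a 3.0-fold higher number from compound 1 to compound 2 (0.48 log units; beyond the scatter); whether the missing fluoro on the core of compound 3 alters the size of the step is not known from these three compounds, so the range is kept wide. Compound 4 is therefore estimated at 600 nM, expected to lie between 250 nM and 1400 nM.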

Compound 4, half-maximal inhibitory concentration: 300 nM
Compound 4: the middle estimate sits 2.0-fold (0.30 log units) above what was measured; measured number inside the range.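

In this assay, acetyl in place of fluoro on the aromatic carbon next to the ring nitrogen gives a 1.4-fold higher number from compound 3 to compound 4 (0.15 log units; within the scatter), and hydrogen in place of fluoro on an aromatic carbon gives a 1.3-fold higher number from compound 2 to compound 4 (0.10 log units; within the scatter), so neither new step is large enough to be told from repeat-measurement noise on its own. Carrying the acetyl change from the core of compound 1 to the core of compound 3 shows no difference in step size that stands clear of the scatter, although only the earlier step lies beyond the scatter by itself: the same change on two cores in this assay, a 3.0-fold higher number (0.48 log units; beyond the scatter) from compound 1 to compound 2 and a 1.4-fold higher number (0.15 log units; within the scatter) from compound 3 to compound 4, 2.1-fold (0.32 log units) apart, within the scatter of two such steps. Two pairs per change show neither that the step is constant across cores nor that it depends on the core, and the hydrogen change reads the same way: the same change on two cores in this assay, a 2.6-fold higher number (0.42 log units; beyond the scatter) from compound 1 to compound 3 and a 1.3-fold higher number (0.10 log units; within the scatter) from compound 2 to compound 4, 2.1-fold (0.32 log units) apart, within the scatter of two such steps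

The compounds shown carry only fluoro, acetyl or hydrogen at the varied places, so it stays open whether an amine, a carboxylic acid or a longer acyl chain at the place next to the ring nitrogen would behave in the same way on both cores. As far as these compounds go, it also stays open whether either change carries over to a core in which the nitrile is replaced by another group, such as a chloro or a methoxy group.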